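The source may report more compounds than this note shows. Statements on the series, on what has been measured and on what is new or still open speak of the compounds shown alone.

Measured so far in a functional assay on DU-145 cells (Homo sapiens) for antiproliferative activity; on this read-out lower numbers stand for higher toxicity in this test and higher numbers for lower toxicity in this test:
compound 1, `CC(=O)Nc1ccc(S(=O)(=O)NNC(=O)c2cccnc2Nc2ccc(Cl)cc2)cc1`, gives > 100000 nM, which is a limit of the assay and not a number.
compound 2, `O=C(NNS(=O)(=O)c1ccc(F)cc1)c1cccnc1Nc1ccc(Cl)cc1Cl`, gives > 100000 nM, also a limit of the assay.

Compound 1 therefore stands at the edge of what this assay can report; both values shown sit at that same edge, as the limit of > 100000 nM in this assay, at which 2 of the 2 values shown sit, records. Neither value is a number from which a direction of change could be read. Compound 3, `O=C(NNS(=O)(=O)c1ccc(Cl)cc1Cl)c1cccnc1Nc1ccc(Cl)cc1`, has not yet been measured. It differs from compound 1 in one place: 2,4-dichlorophenyl in place of 4-acetamidophenyl on a sulfonyl sulfur. Within the data shown here, with the two measured compounds both at the limit, no step between them is available to indicate how large or in which direction the change from compound 1 to compound 3 might move the read-out. The most defensible expectation is that compound 3 behaves as compound 1 does and returns a limit again. The expected step is therefore a number no higher from compound 1 to compound 3 (the limit leaves the size open), nothing beyond the usual scatter. Compound 3 is expected at 100000 nM, with a range from 30000 nM to 300000 nM.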

Compound 3, concentration lethal to 50% of the cells: > 100000 nM
Compound 3: only a limit was reported (the forecaster's own chance of this, stated with the estimate: 80%); the middle value lies on the limit itself.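

No step can be read between compound 1 and compound 3 in this assay, because neither gives a number: the limit of > 100000 nM in this assay, at which 3 of the 3 values shown sit. The compounds shown leave open how far each one lies beyond that limit, and whether any group on the sulfonyl sulfur could bring the read-out in this assay to a measurable number.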